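The compounds below may be only part of what the source reports. "The series", "measured", "known", "first", "only" and "open" are said of these compounds alone.

Working notes on the series. Going by the values given here, in a functional assay on A549 cells (Homo sapiens) for antiproliferative activity, read by MTT assay, with a stated time of 48 h (a lower number here means a stronger inhibitor, a higher number a weaker inhibitor), compound 2 `CCc1ccccc1-n1nncc1CN1C(=O)C2(C(C#N)=C(N)Oc3c(N)cc4nc5ccccc5nc4c32)c2ccccc21` gives 24600 nM, the only number so far in the set. Compound 1 `CC(=O)Nc1ccc(-n2nncc2CN2C(=O)C3(C(C#N)=C(N)Oc4c3c3nc5ccccc5nc3c3ccccc43)c3ccccc32)cc1` gives > 50000 nM in this assay, which is a limit rather than a number; (the limit of > 50000 nM in this assay, at which 1 of the 2 values shown sits). Compound 1 and compound 2 differ in more than one place, so their two values are simply the two readings shown and support no step.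

Compound 3 `N#CC1=C(N)Oc2c(N)cc3nc4ccccc4nc3c2C12C(=O)N(Cc1cnnn1-c1ccc(F)c(Cl)c1)c1ccccc12` is the next compound for this assay. It differs from compound 2 in one place: 3-chloro-4-fluorophenyl in place of 2-ethylphenyl on an aromatic nitrogen. Among the compounds with values here, no measured step with a single change is available to calibrate this exchange, and the only number in hand, that of compound 2, is already weak. For compound 3 the step of a 1.1-fold lower number from compound 2 to compound 3 (0.05 log units; within the scatter) is expected to stay within the scatter, with a real chance that only a limit is reported. Compound 3 is therefore estimated at 22000 nM in this assay, with a range of 8000 nM to 60000 nM.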

Compound 3, half-maximal inhibitory concentration: 43400 nM
The estimate for compound 3 lay 2.0-fold (0.30 log units) below the measured number; measured number inside the range.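

Going by these compounds alone, the exchange of 2-ethylphenyl for 3-chloro-4-fluorophenyl on the aromatic nitrogen of the five-membered ring gives the first step that can be read in this assay: a 1.8-fold higher number from compound 2 to compound 3 (0.25 log units; within the scatter). On the shared core, then, a phenyl ring carrying a carbon chain and one carrying chlorine and fluorine read alike at this position, and the halogens bring no measurable gain. Compound 1 remains a limit rather than a number, and it is the only such reading among the compounds shown: the limit of > 50000 nM in this assay, at which 1 of the 3 values shown sits.

Going by these compounds, whether any group at this position can move the reading out of the weak range stays open: one exchange between two substituted phenyl rings says nothing about an unsubstituted phenyl, a benzyl, or a phenyl bearing an amine or a carboxylic acid. Nor does this single step show whether the same exchange would read alike on a different core.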